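Sulfonamide Series: What Compound 4 Might Show

The source may report more compounds than this note shows. Statements on the series, on what has been measured and on what is new or still open speak of the compounds shown alone.

Measured so far:
- compound 1, `O=S(=O)(NCCNCc1ccc(-c2ccccc2)cc1)c1cc(C(F)(F)F)cc(C(F)(F)F)c1`, gives 2800 nM in a functional assay on ASPC1 cells (Homo sapiens) for inhibition, read by MTT assay, with a stated time of 72 h; on this read-out higher numbers stand for weaker inhibition of growth and lower numbers for stronger inhibition of growth
- compound 2, `O=S(=O)(NCCCCNCc1ccc(Br)cc1)c1cc(C(F)(F)F)cc(C(F)(F)F)c1`, gives 2900 nM in this assay
- compound 3, `O=S(=O)(NCCCNCC1COc2ccccc2O1)c1cc(C(F)(F)F)cc(C(F)(F)F)c1`, gives 2900 nM in this assay

All three compounds share the same sulfonamide core and differ only in the chain and the group at its far end. Compound 2 stands level with compound 3 at the digits shown, and the two together carry the highest numbers of the three. For the measured compounds named here, the gap to compound 1 is so small that it lies within the scatter; on these data no compound can be called stronger or weaker than another.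

Compound 4, `CN(CCCNS(=O)(=O)c1cc(C(F)(F)F)cc(C(F)(F)F)c1)Cc1ccccc1`, has not yet been measured. It differs from compound 2 by benzyl(methyl)amino in place of ((4-bromobenzyl)amino)methyl on a saturated chain carbon, three bonds along the chain from a sulfonamide nitrogen. Going by the values given here, with no measured pair to lean on, the expectation rests on the observation that three quite different chains and end groups gave numbers within the scatter of each other, so a step beyond the scatter in this assay is not expected in either direction. The estimated step from compound 2 is a 1.2-fold higher number from compound 2 to compound 4 (0.08 log units; within the scatter). Compound 4 is thus expected to give about 3500 nM, with a plausible range from 1500 nM to 9000 nM.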

Compound 4, concentration for 50% growth inhibition: 51000 nM
Beside the measured number, compound 4's estimate is 15-fold (1.16 log units) below it; measured number outside the range, above it.
By their numbers in this assay, from the lowest: compounds 1, 2 and 3 (each within the scatter of the next); then compound 4.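

In this assay, putting benzyl(methyl)amino in place of ((4-bromobenzyl)amino)methyl on a saturated chain carbon, three bonds along the chain from a sulfonamide nitrogen, gives an 18-fold higher number from compound 2 to compound 4 (1.25 log units; beyond the scatter), which means much weaker inhibition of growth. The three earlier compounds all sat within the scatter of one another, but this pair shows that the assay can respond strongly to a change at this place. Both groups hold one six-membered aromatic ring of carbon only, so keeping such a ring here does not by itself preserve the activity, while the bromine and the single hydrogen-bond donor of the group that leaves are both absent from the group that enters.

Nothing measured here explains the step. Because the changes travel together, this pair cannot say which one matters, whereas a plain benzylamino group or a (4-bromobenzyl)(methyl)amino group on the same chain would pull apart the bromine and the methyl on the amine nitrogen.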